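A Ring in Place of a Chain on a Shared Core

A few compounds are considered here, and "the series" means these few. Any claim that something is new, unique, unknown or untested is made for them only; others in the source may bear on it.

Compound 3 `NCCNc1c(C(=O)NCc2ccc(F)cc2)nc(Br)c2cccnc12` carries a 2-aminoethyl group on a nitrogen on an aromatic ring. In a functional assay on HCT-116 cells (Homo sapiens) for cytotoxicity, read by MTT assay, with a stated time of 72 h (on this read-out lower numbers stand for stronger inhibition and higher numbers for weaker inhibition), compound 3 gives only a limit, > 20000 nM, and not a number. Among the values shown, this limit of > 20000 nM in this assay, at which 1 of the 3 values shown sits, marks where compound 3 stands. Compound 1 `N[C@H]1CC[C@H](Nc2c(C(=O)NCc3ccc(F)cc3)nc(N3CCCCC3)c3cccnc23)CC1`, which carries the 4-aminocyclohexyl group on the same nitrogen together with a different group elsewhere on the core, gives 8000 nM in this assay. Compound 2 `COC(=O)c1nc(Br)c2cccnc2c1N[C@H]1CC[C@H](N)CC1` gives "not determined" (no result reported) in this assay, so no number is available for it. Compound 4 `N[C@H]1CC[C@H](Nc2c(C(=O)NCc3ccc(F)cc3)nc(Br)c3cccnc23)CC1` is the next step: 4-aminocyclohexyl in place of 2-aminoethyl on a nitrogen on an aromatic ring. For the measured compounds named here, no measured pair shows this exact change, so its size is open. Since compound 1 with the same 4-aminocyclohexyl group reaches 8000 nM, the author expects compound 4 to move toward stronger inhibition, a step of an at least 1.6-fold lower number from compound 3 to compound 4 (0.22 log units; that floor lies within the scatter). Compound 4 is therefore estimated at 12000 nM, with a likely range from 4000 nM to 30000 nM, and a fair chance that only a limit is reported.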

Compound 4, half-maximal inhibitory concentration: 7000 nM
For compound 4 the middle estimate is 1.7-fold (0.23 log units) above the measured one, and the stated range covers the measured number.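

In this assay, with the bromo group held on the shared core, 4-aminocyclohexyl in place of 2-aminoethyl on this nitrogen gives an at least 2.8-fold lower number from compound 3 to compound 4 (0.45 log units; beyond the scatter), a direct reading of this change at one place. With the 4-aminocyclohexyl group kept, bromo in place of piperidin-1-yl on an aromatic carbon gives a 1.1-fold lower number from compound 1 to compound 4 (0.06 log units; within the scatter), so the two groups are not told apart in this read-out. Compound 3 is held only as a limit and not a number, which leaves the step with a floor and no full size: the limit of > 20000 nM in this assay, at which 1 of the 4 values shown sits.

Steps to compound 2 cannot be read, as it has no reported result. The compounds shown leave open whether a longer chain such as 4-aminobutyl, or a cyclohexyl ring without its amine, would give a similar number on this nitrogen.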